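The compounds below may be only part of what the source reports. "The series", "measured", "known", "first", "only" and "open" are said of these compounds alone.

Measured compounds in a functional assay on HCC827 cells (Homo sapiens) for inhibition, read by MTT assay, with a stated time of 48 h, tested at 10 uM; a lower number here means less inhibition, a higher number more inhibition at the concentration tested (going by the name of the read-out):
compound 1, `COc1ccc(Br)cc1Nc1cc(NC(=O)Nc2c(Cl)cccc2Cl)ncn1`, gives 53%;
compound 2, `COc1cc(NC(=O)Nc2cc(Nc3cc(Br)ccc3OC)ncn2)cc(OC)c1`, gives 76.3%;
compound 3, `COc1cc(NC(=O)Nc2cc(Nc3cc(C(F)(F)F)ccc3OC)ncn2)cc(OC)c1`, gives 59.7%.

Compound 2 stands highest of the three numbers, both other values lying beyond the scatter below it. The two measured steps are a number 23.3 percentage points higher from compound 1 to compound 2 (beyond the scatter), where the change sits on the amide-type nitrogen, and a number 16.6 percentage points lower from compound 2 to compound 3 (beyond the scatter), where the change sits on the aromatic carbon of the ring carried by the nitrogen on the aromatic ring.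

Compound 4, `CCc1ccc(Nc2cc(NC(=O)Nc3cc(OC)cc(OC)c3)ncn2)cc1`, is not yet measured. It differs from compound 2 as follows: 4-ethylphenyl in place of 5-bromo-2-methoxyphenyl on a nitrogen on an aromatic ring

The step from compound 2 to compound 3 is the one that bears on this change, since it alters the same ring on the same nitrogen; it was a modest lowering beyond the scatter. Within the data shown here, the change to compound 4 goes further, removing both bromo and methoxy and bringing in ethyl at a different place on that ring, so no direct precedent exists among the three. Among the measured compounds shown here, on the one relevant step, a lowering of roughly similar or somewhat larger size is expected, a number 21.3 percentage points lower from compound 2 to compound 4 (beyond the scatter), with wide uncertainty. Compound 4 is therefore estimated at 55%, in the range 35% to 75%.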

Compound 4, a percentage reported as inhibition, at one concentration (the size of the read-out at that concentration, not a potency): 66.2%
Estimate against measurement, compound 4: 11.2 percentage points below; the range from low to high includes it.
By their numbers in this assay, from the lowest: compounds 1, 3 and 4 (each within the scatter of the next, the first and the last beyond it); then compound 2.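

In this assay, replacing 5-bromo-2-methoxyphenyl with 4-ethylphenyl on the nitrogen on an aromatic ring gives a number 10.1 percentage points lower from compound 2 to compound 4 (beyond the scatter), a modest step for a change of the whole ring substitution. This position therefore keeps a substantial read-out with neither bromo nor methoxy on the ring: compound 4 gives 66.2%, which lies within the scatter of the value of the trifluoromethyl compound 3 at 59.7%, while compound 2 remains above both. Nothing measured here accounts for the step in either direction, and no supporting data bear on it.

This one change removes bromo and methoxy and brings in ethyl together, so the part played by each group cannot be separated with the compounds shown. Also open, as far as these compounds go, are whether a morpholine, a carboxylic acid or a longer chain in place of the ethyl would hold the read-out at this position, and whether 4-ethylphenyl behaves the same way with 2,6-dichlorophenyl on the amide-type nitrogen.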